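Pyridazin-3-yl gives way to 3-fluoropyridin-2-yl

The compounds below may be only part of what the source reports. "The series", "measured", "known", "first", "only" and "open" are said of these compounds alone.

Going by the values given here, in an ADME assay on a cell-free system (plasma, Rattus norvegicus) for metabolic stability, read by LC-MS, with a stated time of 4 h, tested at 100 uM (on this read-out higher numbers stand for a more stable compound and lower numbers for a less stable compound), compound 2 (`Cn1c(Sc2c(F)cc(C(=O)NO)cc2F)nnc1-c1cccnn1`) gives 98%, the highest of the three numbers measured so far. Compound 1 (`Cn1c(Sc2c(F)cc(C(=O)NO)cc2F)nnc1-c1cccs1`) gives 87% and compound 3 (`Cn1c(Sc2c(F)cc(C(=O)NO)cc2F)nnc1-c1cccc(CN2CCCCCC2)c1`) gives 85%, both lower than compound 2 by more than the scatter. Compound 4 (`Cn1c(Sc2c(F)cc(C(=O)NO)cc2F)nnc1-c1ncccc1F`), not yet measured, keeps the shared core and carries 3-fluoropyridin-2-yl in place of pyridazin-3-yl on an aromatic carbon. Among the compounds with values here, one measured step bears on this place, a number 11 percentage points higher from compound 1 to compound 2 (beyond the scatter), and it is modest. Within the data shown here, no measurement yet shows what 3-fluoropyridin-2-yl does here, so the expectation rests on that step and on the narrow spread of the three values, from compound 3 at 85% to compound 2 at 98%. A small fall that stays within the scatter is expected, a number 7 percentage points lower from compound 2 to compound 4 (within the scatter). For compound 4 the estimated value is 91%, with an expected range from 80% to 100%.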

Compound 4, percent of the compound remaining: 100%
Estimate against measurement, compound 4: 9 percentage points below; measured number inside the range.
By their numbers in this assay, from the lowest: compounds 3 and 1 (each within the scatter of the next); then compounds 2 and 4 (each within the scatter of the next).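

In this assay, 3-fluoropyridin-2-yl in place of pyridazin-3-yl gives a number 2 percentage points higher from compound 2 to compound 4 (within the scatter), so at this position on the five-membered aromatic ring the two six-membered rings cannot be told apart, although they differ in hetero atoms and the fluorine is new. Measured against thiophen-2-yl, the same group gives a number 13 percentage points higher from compound 1 to compound 4 (beyond the scatter), so the gain first seen with pyridazin-3-yl now appears with a second nitrogen-bearing six-membered aromatic ring. Nothing available explains why these two groups read alike here.

The compounds shown do not separate the part played by the fluorine from that of the ring nitrogen, as unsubstituted pyridin-2-yl is not among them. Going by these compounds, whether an open-chain amine or a carboxylic acid at this position would keep such numbers also remains open.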